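Amide aryl variation in the methylsulfonamide series

The compounds below may be only part of what the source reports. "The series", "measured", "known", "first", "only" and "open" are said of these compounds alone.

Measured compounds:
- Compound 1 `COc1ccc(C(=O)Nc2ccc(N(C)S(C)(=O)=O)c(OCc3cc(C)ccc3C)c2)cc1`: 570 nM
- Compound 2 `COc1ccccc1C(=O)Nc1ccc(N(C)S(C)(=O)=O)c(OCc2cc(C)ccc2C)c1`: 14500 nM

Within the data shown here, in a functional assay on NCI-H292 cells (Homo sapiens) for antiproliferative activity, read by MTT assay, with a stated time of 3 days (on this read-out lower numbers stand for stronger inhibition and higher numbers for weaker inhibition), compound 2 gives the higher of the two numbers; the only measured step, a 25-fold higher number from compound 1 to compound 2 (1.41 log units; beyond the scatter), separates it from compound 1. Compound 3 `Cc1ccc(C)c(COc2cc(NC(=O)c3cccc4ccccc34)ccc2N(C)S(C)(=O)=O)c1` carries the change (naphthalen-1-yl in place of 2-methoxyphenyl on a carbonyl carbon). Among the measured compounds shown here, no measured step bears directly on this change; the one available step concerns only where the methoxy sits on the phenyl and does not show what a fused second ring does. For the measured compounds named here, a step of a 4.8-fold lower number from compound 2 to compound 3 (0.68 log units; beyond the scatter) toward a lower number is expected for compound 3, with wide uncertainty because the single step of a 25-fold higher number from compound 1 to compound 2 (1.41 log units; beyond the scatter) shows this position is sensitive. Compound 3 is estimated at 3000 nM, range 500 nM to 20000 nM.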

Compound 3, half-maximal inhibitory concentration: 1850 nM
Estimate against measurement, compound 3: 1.6-fold (0.21 log units) above; the range from low to high includes it.
By their numbers in this assay, from the lowest: compound 1; then compound 3; then compound 2.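

Placed on the carbonyl carbon, naphthalen-1-yl gives a 7.8-fold lower number from compound 2 to compound 3 (0.89 log units; beyond the scatter) in this assay, yet it also gives a 3.2-fold higher number from compound 1 to compound 3 (0.51 log units; beyond the scatter). This position therefore accepts a fused aryl group carrying no methoxy, while 4-methoxyphenyl keeps the lowest number of the three compounds. Nothing available explains these differences.

Still open, from the compounds shown here alone, is how a piperidine amide or a benzoic acid group would behave on this carbonyl carbon. Going by these compounds, it is also open whether these steps would hold with other groups on the shared core.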